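A nitrile in place of the sulfonamidophenyl arm

The source may hold more compounds than are shown below. What is called first, only, known or untested is meant among the compounds shown, and "the series" means these compounds.

Compound 3 `CC(C)(N)C(=O)N[C@H](COCc1ccccc1)c1nnn(Cc2ccc(NS(C)(=O)=O)cc2)n1` carries a 4-(methanesulfonamido)phenyl group on the saturated chain carbon bound to an aromatic nitrogen of the shared core. In an assay on isolated protein for displacement of a labelled ligand from growth hormone secretagogue receptor type 1 (Homo sapiens), with a stated time of 1 h (a higher number here means a weaker inhibitor, a lower number a stronger inhibitor), compound 3 gives only a limit, > 5000 nM. Among the measured compounds shown here, that limit is where two of the three values so far sit (the limit of > 5000 nM in this assay, at which 2 of the 3 values shown sit). Compound 4 `CC(C)(N)C(=O)N[C@H](COCc1ccccc1)c1nnn(CC#N)n1` replaces the whole aryl sulfonamide with a nitrile: cyano in place of 4-(methanesulfonamido)phenyl on a saturated chain carbon bound to an aromatic nitrogen.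

For the measured compounds named here, one measured step bears on this change. Compound 1 `CC(C)(N)C(=O)N[C@H](COCc1ccccc1)c1nnnn1CCCCCNS(C)(=O)=O` has a (methanesulfonamido)methyl group on a saturated chain carbon, four bonds along the chain from an aromatic nitrogen, and in this assay compound 1 gives only a limit, > 5000 nM. Compound 2 `CC(C)(N)C(=O)N[C@H](COCc1ccccc1)c1nnnn1CCCCC#N`, with a cyano in that place, gives 3120 nM in this assay. The step of an at least 1.6-fold lower number from compound 1 to compound 2 (0.20 log units; that floor lies within the scatter) thus brought the number from the limit to a measured value, yet its floor lies within the scatter. On these data alone, the change from compound 3 to compound 4 removes a larger group than that one, and the starting point is again a limit, so the size of the step remains open. Compound 4 is expected to give about 3500 nM in this assay, within a range from 1500 nM to 10000 nM. The expected step of an at least 1.4-fold lower number from compound 3 to compound 4 (0.15 log units; that floor lies within the scatter) is therefore a modest lowering, with a real chance that only a limit is reported again.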

Compound 4, inhibition constant: > 5000 nM
Compound 4: no number, only a limit; the forecaster's own chance of this, stated with the estimate: 40%; middle value at least 1.4-fold (0.15 log units) away from the limit.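

In this assay, compound 3 and compound 4 each give only a limit, so no step can be read between them: the limit of > 5000 nM in this assay, at which 3 of the 4 values shown sit.

The compounds shown leave open how far either compound lies past that limit, and so whether cyano in place of 4-(methanesulfonamido)phenyl changes the number at all.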